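The compounds below may be only part of what the source reports. "The series", "measured", "known", "first", "only" and "open" are said of these compounds alone.

The shared core is carried by compound 1 `CCOC(=O)c1ccc(OCc2cc(OC)c(OC)c(OC)c2)cc1`. In a physicochemical assay, with a stated time of 30 min (a lower number here means a stronger inhibitor, a higher number a weaker inhibitor), compound 1 gives only a limit of the assay, > 100 ug/mL, so no number places it within the series. Two hydrazones extend the same core. Compound 2 `COc1cc(COc2ccc(C(=O)N/N=C/c3cc(Br)cc(Cl)c3O)cc2)cc(OC)c1OC` likewise returns only a limit in this assay, > 100 ug/mL. Compound 3 `COc1cc(/C=N/NC(=O)c2ccc(OCc3cc(OC)c(OC)c(OC)c3)cc2)cc(OC)c1O` gives 75 ug/mL in this assay. Within the data shown here, the only measured step, an at least 1.3-fold lower number from compound 2 to compound 3 (0.12 log units; that floor lies within the scatter), is bounded by a limit on one side and lies within the scatter at its floor; it changes the aryl on the carbon double-bonded to nitrogen and does not touch the carbonyl. Compound 4 `COc1cc(COc2ccc(C(=O)N/N=C/c3ccc(O)cc3)cc2)cc(OC)c1OC` is still to be measured. Relative to compound 1 the change is a group of 10 heavy atoms (7 carbon, 2 nitrogen, 1 oxygen; one six-membered aromatic ring of carbon only) in place of a group of 3 heavy atoms (2 carbon, 1 oxygen; no ring), on a carbonyl carbon. Among the measured compounds shown here, no measured step covers this exchange of ethoxy for the larger group on the carbonyl carbon; compounds 2 and 3 only show that hydrazones of this core sit at or close to the limit, as the limit of > 100 ug/mL in this assay, at which 2 of the 3 values shown sit, records. For compound 4 no step beyond the scatter is therefore expected in this assay, and a value at or near the limit is the estimate, 100 ug/mL, between 50 ug/mL and 200 ug/mL. The step of a number no higher from compound 1 to compound 4 (the limit leaves the size open) that this estimate implies is expected to stay within the scatter, with a fair chance that only a limit is reported.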

Compound 4, half-maximal inhibitory concentration: > 100 ug/mL
Compound 4: no number, only a limit; the forecaster's own chance of this, stated with the estimate: 55%; the middle value sits exactly at the limit.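

Among these compounds, replacing 4-hydroxy-3,5-dimethoxyphenyl with 4-hydroxyphenyl on the carbon with a double bond to nitrogen gives, in this assay, an at least 1.3-fold higher number from compound 3 to compound 4 (0.12 log units; that floor lies within the scatter); this is the first reading of this exchange with a hydrazone of the shared core, and it is bounded by a limit on one side. The steps to compound 4 from compound 1 and from compound 2 have limits at both ends and cannot be read, so the exchange of ethoxy for the larger group on the carbonyl carbon still has no size. What compound 4 adds is a third hydrazone of the core, with a plain 4-hydroxyphenyl, that reports no number, leaving compound 3 as the only compound here with a number: the limit of > 100 ug/mL in this assay, at which 3 of the 4 values shown sit.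

As far as these compounds go, whether the number for compound 3 differs from the other compounds by more than the scatter stays open, as their true values lie beyond the range of the assay. Also open, from the compounds shown here alone, is whether a different aryl on the carbon with a double bond to nitrogen, for example one carrying an amine or a carboxylic acid, would bring a hydrazone of this core clearly inside the measurable range.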